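Swapping the benzyl substituent in a sulfonamide series

This account rests on a few compounds, and the source may have more. Where it says the series, first, only, none or still open, it means among the compounds named here.

Compound 1, `O=S(=O)(NCCCNCc1ccc(C(F)(F)F)cc1)c1cc(C(F)(F)F)cc(C(F)(F)F)c1`: 2000 nM
Compound 2, `O=S(=O)(NCCCNCc1ccc(Br)cc1)c1cc(C(F)(F)F)cc(C(F)(F)F)c1`: 2800 nM

In a functional assay on ASPC1 cells (Homo sapiens) for inhibition, read by MTT assay, with a stated time of 72 h (on this read-out lower numbers stand for stronger inhibition of growth and higher numbers for weaker inhibition of growth), compound 2 gives 2800 nM, the higher of the two numbers shown, and compound 1 gives 2000 nM; the step of a 1.4-fold higher number from compound 1 to compound 2 (0.15 log units; within the scatter) keeps the pair within the scatter. Compound 3, `COc1ccc(CNCCCNS(=O)(=O)c2cc(C(F)(F)F)cc(C(F)(F)F)c2)cc1`, carries the change (methoxy in place of bromo on an aromatic carbon). Among the measured compounds shown here, no measured step introduces a methoxy group, so the only guide is that exchanging one group at this position between compound 1 and compound 2 barely moved the number. Compound 3 is therefore expected near compound 2, with an estimated step of a 1.1-fold higher number from compound 2 to compound 3 (0.03 log units; within the scatter) and a value of 3000 nM (1200 nM to 7500 nM).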

Compound 3, concentration for 50% growth inhibition: 2800 nM
For compound 3 the middle estimate is 1.1-fold (0.03 log units) above the measured one, and the stated range covers the measured number.
By their numbers in this assay, from the lowest: compounds 1, 2 and 3 (each within the scatter of the next).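

In this assay, methoxy in place of bromo on an aromatic carbon gives no change at the digits printed from compound 2 to compound 3 (within the scatter) and methoxy in place of trifluoromethyl gives a 1.4-fold higher number from compound 1 to compound 3 (0.15 log units; within the scatter) at the same place. Three different groups at this carbon, now including one that brings an oxygen and a hydrogen-bond acceptor, thus stay within the scatter of each other. Nothing available explains this sameness.

As far as these compounds go, whether an amine or a carboxylic acid at this carbon would stand apart from these three remains open. So does the effect of a longer chain there.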